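Swapping a branched amine arm for an unsaturated oxane-bearing linker

The compounds below may be only part of what the source reports. "The series", "measured", "known", "first", "only" and "open" are said of these compounds alone.

Of the compounds shown here, three sharing one core have been measured in a functional assay on cells for antagonist activity at C-X-C chemokine receptor type 4 (Homo sapiens), read by fluorescence and calcium flux, with stated times of 25 min and 90 s; a lower number here means a stronger inhibitor, a higher number a weaker inhibitor. Compound 1 `c1ccc2c(c1)CN[C@@H](CN(CCCCNCc1ccncc1)[C@H]1CCCc3cccnc31)C2` gives 22.7 nM. Compound 2 `c1ccc2c(c1)CN[C@@H](CN(CCCCNC1CCOCC1)[C@H]1CCCc3cccnc31)C2` gives 29.4 nM, and the step of a 1.3-fold higher number from compound 1 to compound 2 (0.11 log units; within the scatter) shows that the exchange of (pyridin-4-yl)methyl for oxan-4-yl hardly registers. Compound 3 `CC(C)(CN)CCN(C[C@H]1Cc2ccccc2CN1)[C@H]1CCCc2cccnc21` gives 69 nM, the highest number of the three, with the steps of a 3.0-fold higher number from compound 1 to compound 3 (0.48 log units; beyond the scatter) and a 2.3-fold higher number from compound 2 to compound 3 (0.37 log units; beyond the scatter) both modest but beyond the scatter.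

Compound 4 `C(=C/CN(C[C@H]1Cc2ccccc2CN1)[C@H]1CCCc2cccnc21)\CNC1CCOCC1` has not yet been measured. The change 3-((oxan-4-yl)amino)prop-1-en-1-yl in place of 2-(aminomethyl)-2-methylpropyl on a saturated chain carbon bound to an amine nitrogen restores the oxan-4-ylamino motif of compound 2, now on a three-carbon chain carrying a double bond rather than a fully saturated four-carbon one. Going by the values given here, the step from compound 2 to compound 3 is the relevant comparison, read in reverse, since no measured pair reports on the double bond itself. A modest fall in the number back toward compound 2 is therefore expected, a 2.0-fold lower number from compound 3 to compound 4 (0.29 log units; within the scatter), giving for compound 4 an estimated 35 nM in this assay, within the range 15 nM to 90 nM.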

Compound 4, half-maximal inhibitory concentration: 15.5 nM
The estimate for compound 4 lay 2.3-fold (0.35 log units) above the measured number; low and high end bracket the measured number.
By their numbers in this assay, from the lowest: compounds 4, 1 and 2 (each within the scatter of the next); then compound 3.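

In this assay, the step of a 4.5-fold lower number from compound 3 to compound 4 (0.65 log units; beyond the scatter) shows that this position on the saturated chain carbon bound to an amine nitrogen responds to the exchange of the branched 2-(aminomethyl)-2-methylpropyl for 3-((oxan-4-yl)amino)prop-1-en-1-yl. Going by these compounds alone, the step of a 1.9-fold lower number from compound 2 to compound 4 (0.28 log units; within the scatter) is the first direct reading on the double bond, and it stays within the scatter, so the chain accepts this double bond without a measurable change. The step of a 1.5-fold lower number from compound 1 to compound 4 (0.17 log units; within the scatter) is also within the scatter, which places the unsaturated oxane arm level with the saturated arm carrying (pyridin-4-yl)methyl.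

Still open, as far as these compounds go, is how a triple bond in this chain, or a piperidine ring in place of the oxane ring, would read. No supporting data explain why the branched arm gives the higher number.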